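The compounds below may be only part of what the source reports. "The series", "measured", "known", "first", "only" and "open" are said of these compounds alone.

For the measured compounds named here, in a functional assay on T98G cells (Homo sapiens) for cytotoxicity, read by MTT assay, with a stated time of 48 h (a lower number here means a stronger inhibitor, a higher number a weaker inhibitor), compound 1 `C/C(=N\NC(=S)Nc1ccccc1[N+](=O)[O-])c1ccccn1` gives 6.61 nM, the lowest of the two numbers measured so far. Compound 2 `C/C(=N\NC(=S)Nc1cccc([N+](=O)[O-])c1)c1ccccn1` gives 140 nM in this assay, a far higher number that lies well beyond the scatter of repeated measurements. Compound 3 `C/C(=N/NC(=S)Nc1ccccc1[N+](=O)[O-])c1ccccn1` has not yet been measured in this assay. The change from compound 1 to compound 3 is the two compounds have the same atoms and bonds and differ only in configuration as drawn: 1 of 1 stereo elements differ; a double bond is drawn E in compound 1 and Z in compound 3; the two compounds have the same atoms and bonds and differ only in configuration as drawn. Going by the values given here, no step between two measured compounds of this kind is available, so the expectation rests on compound 1 alone. Since compound 1 gives 6.61 nM and the change is confined to how one double bond is drawn, compound 3 is expected to stay close, with an expected step of a 1.5-fold higher number from compound 1 to compound 3 (0.18 log units; within the scatter) that may not exceed the scatter. Compound 3 is therefore estimated at 10 nM, with a range from 3 nM to 40 nM.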

Compound 3, half-maximal inhibitory concentration: 6.61 nM
Compound 3: the middle estimate sits 1.5-fold (0.18 log units) above what was measured, and the stated range covers the measured number.
By their numbers in this assay, from the lowest: compounds 1 and 3 (each within the scatter of the next); then compound 2.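

In this assay, redrawing the double bond from E to Z gives no change at the digits printed from compound 1 to compound 3 (within the scatter), so in this pair the drawn configuration of that bond leaves no mark on the number. Compounds 1 and 2 could not show this, since both carry the same drawing of the double bond and differ in where the nitro group sits, with compound 1 at 6.61 nM and compound 2 at 140 nM. The reading is clean in one respect, as nothing else separates the new pair: the fact that compounds 1 and 3 differ only in the configuration as drawn

On these data alone, whether the same redrawing would leave compound 2 just as unaffected remains open. So does what an amine or a methoxy group would give in place of the nitro group.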